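This account rests on a few compounds, and the source may have more. Where it says the series, first, only, none or still open, it means among the compounds named here.

Working notes on the series. Compound 1 `Cc1c(Cc2ccccc2)c(=O)oc2cc(OCC(O)CNCC3CC3)ccc12` is the reference point. In an ADME assay on A549 cells (Homo sapiens) for cytotoxicity, read by CellTiter-Glo (a lower number here means that less compound is tolerated, a higher number that more compound is tolerated), compound 1 gives > 100000 nM, which is a limit of the assay and not a number. Compound 2 `Cc1c(Cc2ccccc2)c(=O)oc2cc(OCC(O)CNc3cc([N+](=O)[O-])ccc3O)ccc12` and compound 3 `Cc1c(Cc2ccccc2)c(=O)oc2cc(OCC(O)CNc3nc4ccccc4[nH]3)ccc12` are the other measured members. In this assay compound 2 gives > 100000 nM, again a limit. In this assay compound 3 gives > 100000 nM, also a limit. The steps a step that the two limits leave unreadable from compound 1 to compound 2, a step that the two limits leave unreadable from compound 1 to compound 3 and a step that the two limits leave unreadable from compound 2 to compound 3 therefore carry no readable size, because every value shown sits at the limit of > 100000 nM in this assay, at which 3 of the 3 values shown sit.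

Compound 4 `Cc1c(Cc2ccccc2)c(=O)oc2cc(OCCCNc3nccs3)ccc12` is the next member to be measured. It differs from compound 1 by 2-((1,3-thiazol-2-yl)amino)ethyl in place of 2-((cyclopropylmethyl)amino)-1-hydroxyethyl on a saturated chain carbon bound to an oxygen on an aromatic ring. The measured steps that bear on it are those that exchange the group on the amine nitrogen, and none of them gave a readable size. Compound 4 is accordingly expected to sit at the same limit, with a number no higher from compound 1 to compound 4 (the limit leaves the size open) expected to show nothing beyond the scatter. The estimate for compound 4 in this assay is 100000 nM, within a range from 40000 nM to 250000 nM.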

Compound 4, half-maximal cytotoxic concentration: 50100 nM
Compound 4: middle estimate off by 2.0-fold (0.30 log units), on the high side; measured number inside the range.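

In this assay, within the data shown here, compound 4 gives 50100 nM as the first number that is not a limit. Among these compounds, the exchange of 2-((cyclopropylmethyl)amino)-1-hydroxyethyl for 2-((1,3-thiazol-2-yl)amino)ethyl on a saturated chain carbon bound to an oxygen on an aromatic ring gives an at least 1.9-fold lower number from compound 1 to compound 4 (0.30 log units; that floor lies within the scatter) and is thus the first step here with a readable floor, unlike the unreadable exchanges on the amine nitrogen. As far as these compounds go, the full size of the step stays open because compound 1 carries only a limit: the limit of > 100000 nM in this assay, at which 3 of the 4 values shown sit.

This step alters the hydroxyl-bearing chain and the group on the amine nitrogen together, and the compounds shown do not separate the two. A 3-((1,3-thiazol-2-yl)amino)-2-hydroxypropyl chain or a longer chain ending in the same thiazolyl amine would bear on that question.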